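A few compounds are considered here, and "the series" means these few. Any claim that something is new, unique, unknown or untested is made for them only; others in the source may bear on it.

Compound 2 `COC(=O)C[C@H](NC(=O)OC(C)(C)C)C(=O)N(Cc1ccc(F)cc1)C1(C(=O)NC(C)(C)C)CCN(Cc2ccccc2)CC1` has been tested in an ADME assay on MDCK cells (Canis lupus familiaris) for cytotoxicity, read by microscopy, with a stated time of 72 h; on this read-out higher numbers stand for lower toxicity in this test and lower numbers for higher toxicity in this test. In this assay compound 2 gives 80000 nM. For the measured compounds named here, its only neighbour, compound 1 `COC(=O)C[C@H](NC(=O)OC(C)(C)C)C(=O)N(Cc1ccc(F)cc1)C1(C(=O)NC2CCCCC2)CCN(Cc2ccccc2)CC1`, gives 100000 nM. The two values lie within the scatter of each other, the step from one to the other being a 1.3-fold lower number from compound 1 to compound 2 (0.10 log units; within the scatter). Compound 3 `COC(=O)C[C@H](NC(=O)OC(C)(C)C)C(=O)N(Cc1ccc(F)cc1)C1(C(=O)NCS(=O)(=O)c2ccc(C)cc2)CCN(Cc2ccccc2)CC1` has not yet been measured. It differs from compound 2 by ((4-methylphenyl)sulfonyl)methyl in place of tert-butyl on an amide-type nitrogen. Going by the values given here, the single measured step, which also swaps the group on an amide-type nitrogen, stayed within the scatter. Compound 3 is therefore expected to move by no change at the digits printed from compound 2 to compound 3 (within the scatter), not beyond the scatter. Compound 3 is estimated at 80000 nM, between 30000 nM and 200000 nM.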

Compound 3, minimum cytotoxic concentration: 4000 nM
The estimate for compound 3 lay 20-fold (1.30 log units) above the measured number, and the stated range ends above it.
By their numbers in this assay, from the lowest: compound 3; then compounds 2 and 1 (each within the scatter of the next).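

In this assay the group on the amide-type nitrogen proves able to shift the read-out, with a 20-fold lower number from compound 2 to compound 3 (1.30 log units; beyond the scatter) and a 25-fold lower number from compound 1 to compound 3 (1.40 log units; beyond the scatter) when ((4-methylphenyl)sulfonyl)methyl enters, towards higher toxicity in this test. The exchange of cyclohexyl and tert-butyl had not shown this. No evidence is available on what underlies the shift. The compounds shown leave open whether the sulfonyl or the aromatic ring carries the effect, and whether a plain benzyl or a methylsulfonylmethyl group on this nitrogen would lower the number as well.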